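A few compounds are considered here, and "the series" means these few. Any claim that something is new, unique, unknown or untested is made for them only; others in the source may bear on it.

Two compounds share one core and differ only in the ring attached to the benzamide end. Compound 1, `CCOC(=O)CCCCCOc1cccc(CN(C(=O)c2ccc(-c3ccoc3)cc2)C(C)C)c1`, carries a furan-3-yl group there. In an ADME assay on Raji cells (Homo sapiens) for cytotoxicity, read by CellTiter-Glo and resazurin assay, with a stated time of 72 h (a higher number here means that more compound is needed for the effect, a lower number that less compound is needed), compound 1 reaches only the limit of the assay, > 26000 nM, which is a bound and not a number. Compound 2, `CCOC(=O)CCCCCOc1cccc(CN(C(=O)c2ccc(-c3cccc(OC)c3)cc2)C(C)C)c1`, carries a 3-methoxyphenyl group in place of the furan-3-yl. In this assay compound 2 likewise stops at a limit, > 21000 nM. The step that the two limits leave unreadable from compound 1 to compound 2 therefore cannot be read, because the limit of > 21000 nM in this assay, at which 1 of the 2 values shown sits, and the limit of > 26000 nM in this assay, at which 1 of the 2 values shown sits, mark both of its ends. For the measured compounds named here, compound 2 thus stands at a bound, and so does the only other compound measured.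

Compound 3, `CCOC(=O)CCCCCOc1cccc(CN(C(=O)c2ccc(-c3cccc(OCC)c3)cc2)C(C)C)c1`, departs from compound 2 by a single change: methyl in place of hydrogen on a saturated chain carbon bound to an oxygen on an aromatic ring, turning 3-methoxyphenyl into 3-ethoxyphenyl. Going by the values given here, the only measured step touching this region is unreadable, so no movement beyond the scatter can be grounded. The expected step that the limit leaves unreadable from compound 2 to compound 3 is accordingly estimated to lie within the scatter. Compound 3 is expected to give about 30000 nM in this assay, estimated between 10000 nM and 100000 nM, most likely again as a limit.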

Compound 3, half-maximal effective concentration: > 22300 nM
Compound 3: no number, only a limit (the forecaster's own chance of this, stated with the estimate: 85%); the middle value does not contradict the limit.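

In this assay compound 3 also gives only a limit, so the steps linking compound 3 to compound 1 and to compound 2 cannot be read. The compounds shown leave open how much of compound 1, compound 2 or compound 3 would be needed for the effect, and whether exchanging the ring or going from methoxy to ethoxy changes that amount at all.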